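This account rests on a few compounds, and the source may have more. Where it says the series, first, only, none or still open, it means among the compounds named here.

Compound 1 `CC[C@@H]1C(=O)N(C)c2cnc(Nc3ccc(S(=O)(=O)NCCO)cc3)nc2N1C1CCCC1` gives 2100 nM.
Compound 2 `CC[C@@H]1C(=O)N(C)c2cnc(Nc3ccc(S(=O)(=O)NC4CCCC4)cc3)nc2N1C1CCCC1` gives 1710 nM.
Compound 3 `CC[C@@H]1C(=O)N(C)c2cnc(Nc3ccc(S(N)(=O)=O)cc3)nc2N1C1CCCC1` gives 5290 nM.

All three numbers come from a functional assay on NCI-H1975 cells (Homo sapiens) for antiproliferative activity, read by CCK-8 assay, with a stated time of 72 h; a higher number here means a weaker inhibitor of growth, a lower number a stronger inhibitor of growth. Compound 3 stands at the highest number of the three, so it is the weakest inhibitor of growth in this small set: the step of a 2.5-fold higher number from compound 1 to compound 3 (0.40 log units; beyond the scatter) and the step of a 3.1-fold higher number from compound 2 to compound 3 (0.49 log units; beyond the scatter) both lie beyond the scatter, while the step of a 1.2-fold lower number from compound 1 to compound 2 (0.09 log units; within the scatter) stays within it, so the two substituted compounds cannot be told apart.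

Compound 4 `CC[C@@H]1C(=O)N(C)c2cnc(Nc3ccc(S(=O)(=O)NCC(C)C)cc3)nc2N1C1CCCC1` differs from compound 3 in one place: isobutyl in place of hydrogen on a sulfonamide nitrogen. The two measured steps that bear on this are the ones just named, since each of them also sets a substituent against a hydrogen on the same sulfonamide nitrogen, and in both cases the substituted compound carries the lower number by a modest margin. Whether that substituent carries a ring or a hydroxyl seems to matter little, as compounds 1 and 2 show. An isobutyl group is therefore expected to behave like those two, giving a modest lowering of the number, a 2.8-fold lower number from compound 3 to compound 4 (0.44 log units; beyond the scatter). The estimate for compound 4 in this assay is 1900 nM, with a likely range from 900 nM to 4000 nM.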

Compound 4, concentration for 50% growth inhibition: 1040 nM
The estimate for compound 4 lay 1.8-fold (0.26 log units) above the measured number; low and high end bracket the measured number.
By their numbers in this assay, from the lowest: compounds 4, 2 and 1 (each within the scatter of the next, the first and the last beyond it); then compound 3.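

Isobutyl on the sulfonamide nitrogen gives a 5.1-fold lower number from compound 3 to compound 4 (0.71 log units; beyond the scatter) in this assay and so shows that a substituent with no ring and no hydroxyl also separates clearly from the bare hydrogen. Set against the earlier substituents, the step of a 1.6-fold lower number from compound 2 to compound 4 (0.22 log units; within the scatter) stays within the scatter, so isobutyl and cyclopentyl cannot be told apart, while the step of a 2.0-fold lower number from compound 1 to compound 4 (0.31 log units; beyond the scatter) lies just beyond it and gives the first sign that the kind of substituent can matter, not only its presence. Nothing shown here gives a measured reason for these differences.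

The compounds shown leave open how a longer chain, such as n-hexyl, would behave on this nitrogen. They also leave open what a chain ending in an amine or a carboxylic acid would do to the number.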